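Swapping cyclopropyl for isopropyl on the shared core

The source may hold more compounds than are shown below. What is called first, only, known or untested is meant among the compounds shown, and "the series" means these compounds.

Three compounds built on a shared core were tested in a functional assay on A-375 cells (Homo sapiens) for antiproliferative activity, read by MTT assay, with a stated time of 72 h; a higher number here means a weaker inhibitor, a lower number a stronger inhibitor. Compound 1 `O=C1COc2ccc(-c3cccc(NS(=O)(=O)c4ccc(F)cc4)c3)cc2N1C1CC1` carries a cyclopropyl on the amide-type nitrogen in its ring. In this assay compound 1 gives > 40000 nM, which is a limit of the assay rather than a number. Compound 2 `O=C1COc2ccc(-c3cnc4ccccc4c3)cc2N1c1ccccc1` also reaches only the limit, > 40000 nM. Compound 3 `O=C1COc2ccc(-c3cnc(Cl)c(NS(=O)(=O)c4ccc(F)cc4)c3)cc2N1C1CCCCC1` likewise gives the limit > 40000 nM. So compound 1 stands exactly where the other two measured compounds stand, as the one piece of evidence shows: the limit of > 40000 nM in this assay, at which 3 of the 3 values shown sit. Going by the values given here, no step between two measured compounds exists, so nothing is known about how far any single change moves this assay.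

Compound 4 `CC(C)N1C(=O)COc2ccc(-c3cccc(NS(=O)(=O)c4ccc(F)cc4)c3)cc21` has not yet been measured. It differs from compound 1 by isopropyl in place of cyclopropyl on an amide-type nitrogen in a ring. With all three measured values sitting at the limit, no movement beyond the scatter is expected, and the step that the limit leaves unreadable from compound 1 to compound 4 is expected to be essentially none. Compound 4 is therefore estimated at 50000 nM, with a range from 20000 nM to 150000 nM, and most likely reported again only as a limit.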

Compound 4, half-maximal inhibitory concentration: > 40000 nM
Compound 4: only a limit was reported; the forecaster's own chance of this, stated with the estimate: 85%; the middle value is on the limit's open side.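

In this assay, going by these compounds alone, compound 1 and compound 4 both stop at a limit rather than a number, so swapping cyclopropyl for isopropyl gives no step that can be read: the limit of > 40000 nM in this assay, at which 4 of the 4 values shown sit. The compounds shown leave open which change to the shared core, if any, would bring a measurable value.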